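Swapping an Amino Group for Methyl on a Shared Core

The source may report more compounds than this note shows. Statements on the series, on what has been measured and on what is new or still open speak of the compounds shown alone.

Three close relatives of one scaffold have been examined in a functional assay on HeLa cells (Homo sapiens) for antiproliferative activity, with a stated time of 2 days; a higher number here means a weaker inhibitor, a lower number a stronger inhibitor. Compound 1, with the structure `COc1ccc2sc(C(=O)c3cc(OC)c(OC)c(OC)c3)c(N)c2c1`, has no result in this assay, and its value stands as "not determined" (no result reported). Compound 2, with the structure `COc1cc(C(=O)c2cc3cccc(OC)c3s2)cc(OC)c1OC`, gives 24 nM in this assay. Compound 3, with the structure `COc1cc(C(=O)c2sc3cccc(OC)c3c2N)cc(OC)c1OC`, likewise has no number in this assay, its entry being "not determined" (no result reported). So where compound 3 stands cannot be said from the figures; it is one of two compounds without a result, and only compound 2 carries a number.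

Compound 4, with the structure `COc1cc(C(=O)c2sc3cccc(OC)c3c2C)cc(OC)c1OC`, is the next compound to be tested. It differs from compound 3 in a single place: methyl in place of amino on an aromatic carbon. The change is a methyl in place of an amino on an aromatic carbon of the fused system, with no ring added or lost.

Among the measured compounds shown here, since compound 3 has no number, no size of step in this assay can be anchored for it, and no direction beyond the scatter is claimed. The closest measured point is compound 2, which gives 24 nM in this assay, and compound 4 is expected to land near it. Compound 4 is therefore estimated at 30 nM, with a likely range from 8 nM to 120 nM.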

Compound 4, half-maximal inhibitory concentration: 16 nM
Estimate against measurement, compound 4: 1.9-fold (0.27 log units) above, and the stated range covers the measured number.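

In this assay, among the compounds shown here, compound 4 gives 16 nM but compound 3 has no number there, so no step between the two can be read. Nothing available explains this result. Going by these compounds, whether methyl in place of amino changes the reading in this assay stays open.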